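From 4-fluorophenyl to 3,5-dimethylphenyl on a sulfur

A few compounds are considered here, and "the series" means these few. Any claim that something is new, unique, unknown or untested is made for them only; others in the source may bear on it.

In a functional assay on HeLa cells (Homo sapiens) for antiproliferative activity, read by CCK-8 assay, with a stated time of 72 h (on this read-out lower numbers stand for stronger inhibition and higher numbers for weaker inhibition), compound 3 (`Nc1ccccc1NC(=O)c1ccc(CSc2ccc(F)cc2)cc1`) gives 5010 nM and so stands within the scatter of both compound 1 (`CCc1ccc(SCc2ccc(C(=O)Nc3ccccc3N)cc2)cc1`) with 3800 nM and compound 2 (`Nc1ccccc1NC(=O)c1ccc(CSCCc2ccccc2)cc1`) with 6430 nM in this small set. Compound 4 (`Cc1cc(C)cc(SCc2ccc(C(=O)Nc3ccccc3N)cc2)c1`) carries 3,5-dimethylphenyl in place of 4-fluorophenyl on a sulfur. Three measured exchanges on that sulfur bear on this change: a 1.3-fold higher number from compound 1 to compound 3 (0.12 log units; within the scatter) and a 1.7-fold higher number from compound 1 to compound 2 (0.23 log units; within the scatter) and also a 1.3-fold lower number from compound 2 to compound 3 (0.11 log units; within the scatter) all stayed small. No step beyond the scatter is therefore expected in this assay for this exchange. The estimated step is a 1.1-fold lower number from compound 3 to compound 4 (0.05 log units; within the scatter) and is expected to be of similar size. For compound 4 the estimated value is 4500 nM with an expected range from 2200 nM to 9000 nM on this measure.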

Compound 4, half-maximal inhibitory concentration: 2090 nM
Beside the measured number, compound 4's estimate is 2.2-fold (0.33 log units) above it; measured number below the stated range.
By their numbers in this assay, from the lowest: compounds 4, 1, 3 and 2 (each within the scatter of the next, the first and the last beyond it).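

In this assay, for the compounds shown here, the sulfur position shows steps beyond the scatter for the first time: a 2.4-fold lower number from compound 3 to compound 4 (0.38 log units; beyond the scatter) and a 3.1-fold lower number from compound 2 to compound 4 (0.49 log units; beyond the scatter) are the first exchanges here to leave it. Against 4-ethylphenyl, however, a 1.8-fold lower number from compound 1 to compound 4 (0.26 log units; within the scatter) shows no such separation. No measurement at hand explains these steps.

The compounds shown leave open whether one methyl group, as in 3-methylphenyl, would give the same result as the 3,5-dimethylphenyl group. They also leave open how an amine or a carboxylic acid on that aromatic ring would compare.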